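The source may report more compounds than this note shows. Statements on the series, on what has been measured and on what is new or still open speak of the compounds shown alone.

Measured compounds in a functional assay on MCF7 cells (Homo sapiens) for antiproliferative activity, read by MTT assay, with a stated time of 48 h; a higher number here means a weaker inhibitor, a lower number a stronger inhibitor:
- compound 1 `O=C(Nc1cccc(/C=C/C(=O)c2nc3ccccc3[nH]2)c1)c1ccccc1`, which gives 11200 nM
- compound 2 `O=C(/C=C/c1cccc(NC(=O)c2ccccc2Cl)c1)c1nc2ccccc2[nH]1`, which gives 4570 nM
- compound 3 `O=C(Nc1cccc(/C=C/C(=O)c2nc3ccccc3[nH]2)c1)c1ccc(Cl)cc1`, which gives 8410 nM

Compound 3 stands second highest of these three numbers in this assay. Its nearest neighbour is compound 1, from which it is separated by a 1.3-fold lower number from compound 1 to compound 3 (0.12 log units; within the scatter); the furthest is compound 2, separated by a 1.8-fold higher number from compound 2 to compound 3 (0.26 log units; within the scatter). Neither gap is large enough to count as a real difference.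

Compound 4 `O=C(/C=C/c1cccc(NC(=O)c2ccccc2Br)c1)c1nc2ccccc2[nH]1` differs from compound 3 in one place: 2-bromophenyl in place of 4-chlorophenyl on a carbonyl carbon. Among the measured compounds shown here, two measured steps bear on this. The step from compound 2 to compound 3 moved the halogen from the 2-position to the 4-position of the benzamide ring, a 1.8-fold higher number from compound 2 to compound 3 (0.26 log units; within the scatter), and compound 4 reverses that placement. The step of a 2.5-fold lower number from compound 1 to compound 2 (0.39 log units; beyond the scatter) shows that a 2-chlorophenyl amide gave the lowest number of the set. For the measured compounds named here, compound 4 carries bromine rather than chlorine at that position; no measured pair here tests a bromine-for-chlorine exchange, so that part of the change is untested. A modest lowering of the number is therefore expected, a 1.7-fold lower number from compound 3 to compound 4 (0.23 log units; within the scatter), towards the value of compound 2. Compound 4 is estimated at 5000 nM, within the range 2000 nM to 12000 nM.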

Compound 4, half-maximal inhibitory concentration: 4520 nM
The estimate for compound 4 lay 1.1-fold (0.04 log units) above the measured number; measured number inside the range.
By their numbers in this assay, from the lowest: compounds 4, 2, 3 and 1 (each within the scatter of the next, the first and the last beyond it).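

In this assay, bromo in place of chloro gives the first direct test of this exchange on the amide ring (compare a 1.0-fold lower number from compound 2 to compound 4 (0.00 log units; within the scatter)), and the 2-chlorophenyl and 2-bromophenyl groups cannot be told apart at this place. The bromine also reproduces the gap seen with chlorine when hydrogen is replaced (see a 2.5-fold lower number from compound 1 to compound 4 (0.39 log units; beyond the scatter)), so both of these halogen-bearing groups now stand beyond the scatter from the hydrogen compound. The exchange of 4-chlorophenyl for 2-bromophenyl (here a 1.9-fold lower number from compound 3 to compound 4 (0.27 log units; within the scatter)) stays within the scatter, so it does not firmly separate these two compounds. No measurement shown accounts for these numbers. From the compounds shown here alone, it remains open whether a 2-methoxyphenyl or 2-aminophenyl group on this carbonyl carbon would match the two halogens, and a 4-bromophenyl group would test whether bromine behaves like chlorine at that other ring position.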